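Swapping a para methoxy for nitro on a picomolar binder

A few compounds are considered here, and "the series" means these few. Any claim that something is new, unique, unknown or untested is made for them only; others in the source may bear on it.

Measured compounds:
compound 1, `COc1ccc(Nc2cncc(N3CC4CC(C3)N4)c2)cc1`: 0.0598 nM
compound 2, `c1ccc(Nc2ccc(N3CC4CC(C3)N4)cn2)cc1`: 2.66 nM

In an assay on cell membranes for displacement of a labelled ligand from Neuronal acetylcholine receptor; alpha4/beta2 (Rattus norvegicus) (on this read-out lower numbers stand for stronger inhibition and higher numbers for weaker inhibition), compound 1 gives the lowest of the two numbers, and the gap to compound 2 lies beyond the usual scatter. Compound 3, `O=[N+]([O-])c1ccc(Nc2cncc(N3CC4CC(C3)N4)c2)cc1`, differs from compound 1 in one place: nitro in place of methoxy on an aromatic carbon, so nitro in place of methoxy on an aromatic carbon. Among the measured compounds shown here, no comparable step has been measured here, so the expected step from compound 1 to compound 3 is taken as small, leaning slightly toward a higher number: a 1.7-fold higher number from compound 1 to compound 3 (0.22 log units; within the scatter). Compound 3 is therefore estimated at 0.1 nM, in a range from 0.02 nM to 0.5 nM.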

Compound 3, inhibition constant: 0.0225 nM
The estimate for compound 3 lay 4.4-fold (0.65 log units) above the measured number; the range from low to high includes it.
By their numbers in this assay, from the lowest: compound 3; then compound 1; then compound 2.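

Compound 1 already gave a very low number in this assay, yet nitro in place of methoxy went further still, with a 2.7-fold lower number from compound 1 to compound 3 (0.42 log units; beyond the scatter) as a modest step. This position, on an aromatic carbon para to a large group, therefore accepts a group with more heavy atoms and hydrogen-bond acceptors with no loss of binding. Nothing measured here explains the direction of this step.
Going by these compounds, whether an amine or a carboxylic acid at this position would also keep the number this low remains open. A single step also cannot show whether the same swap would give the same result on another core.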